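A few compounds are considered here, and "the series" means these few. Any claim that something is new, unique, unknown or untested is made for them only; others in the source may bear on it.

Measured compounds:
compound 1, `COc1ccc(-c2cc(C(C)=O)c3[nH]c(-c4ccccc4)cc3c2)cc1`, 99.2%
compound 2, `COc1ccc(-c2cc3cc(-c4ccccc4)cc(C(C)=O)c3[nH]2)cc1`, 87%
compound 3, `COc1ccc(-c2cc3cc(-c4ccc(F)cc4)cc(C(C)=O)c3[nH]2)cc1`, 97.3%

The three compounds were all tested in a functional assay on MCF7 cells (Homo sapiens) for cytotoxicity, read by MTT assay, with a stated time of 2 days, tested at 0.1 uM; a higher number here means a weaker effect of the compound at the concentration tested, a lower number a stronger effect. Compound 1 gives 99.2%, compound 2 gives 87% and compound 3 gives 97.3%. Compound 3 therefore stands second highest of the three numbers: its value and that of compound 1 lie within the scatter of each other, whereas the step of a number 10.3 percentage points higher from compound 2 to compound 3 (beyond the scatter) is beyond the scatter, though modest.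

Compound 4, `COc1ccc(-c2cc(C(C)=O)c3[nH]c(-c4ccc(OC)cc4)cc3c2)cc1`, is not yet measured. It differs from compound 3 at a single place: methoxy in place of fluoro on an aromatic carbon.

Within the data shown here, only one measured step bears on this change, and only loosely. The step of a number 10.3 percentage points higher from compound 2 to compound 3 (beyond the scatter) shows that putting a fluoro on this aromatic carbon raised the number by a modest amount. Among the measured compounds shown here, nothing measured here shows what a methoxy does at the same place, so there is no direct precedent. All three numbers sit close to the top of the scale: compound 2 gives 87% and compound 1 gives 99.2%. Compound 4 is therefore expected to land in the same region, and the step of a number 2.3 percentage points lower from compound 3 to compound 4 (within the scatter) is expected to stay within the scatter. Compound 4 is thus estimated to give 95%, with a range from 84% to 102%.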

Compound 4, a percentage reported as activity, at one concentration (the size of the read-out at that concentration, not a potency): 96.5%
For compound 4 the middle estimate is 1.5 percentage points below the measured one; measured number inside the range.
By their numbers in this assay, from the lowest: compounds 2, 4, 3 and 1 (each within the scatter of the next, the first and the last beyond it).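

In this assay the exchange of fluoro for methoxy on this aromatic carbon, para to a large group, gives a number 0.8 percentage points lower from compound 3 to compound 4 (within the scatter), so the 4-fluorophenyl and 4-methoxyphenyl forms cannot be told apart at the concentration tested. Methoxy in place of hydrogen can now be read from two sides, as a number 9.5 percentage points higher from compound 2 to compound 4 (within the scatter) and as a number 2.7 percentage points lower from compound 1 to compound 4 (within the scatter), and neither step goes beyond the scatter, whereas the earlier fluoro step, a number 10.3 percentage points higher from compound 2 to compound 3 (beyond the scatter), was printed as beyond it, though only modestly. The new compound thus adds a second substituent at this position without showing a clear change in the read-out, and no measurement at hand offers an explanation for these numbers.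

On these data alone, whether an amine, a carboxylic acid or a longer chain on this aromatic carbon would leave the read-out in the same region remains open. Also open, as far as these compounds go, is how these compounds would compare at other concentrations, since a single-concentration read-out near the top of the scale gives no measure of potency.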